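This account rests on a few compounds, and the source may have more. Where it says the series, first, only, none or still open, it means among the compounds named here.

Compound 1 `CCCCCNc1nc(N)c2nc(O)n(Cc3ccccc3)c2n1`: 0.3 mg/kg
Compound 2 `CCCCOc1nc(N)c2[nH]c(=O)n(Cc3ccccc3)c2n1`: 0.1 mg/kg
Compound 3 `CSc1nc(N)c2nc(O)n(Cc3ccccc3)c2n1`: 0.1 mg/kg

All three compounds share one core and were tested in a functional assay on the whole organism for activation, with Mus musculus as the target; a higher number here means that more compound is needed for the effect, a lower number that less compound is needed. Compound 3 gives 0.1 mg/kg, level at the digits printed with compound 2 and together with it the lowest of the three numbers. Compound 1 gives 0.3 mg/kg, the highest of the three. Within the data shown here, the only single-point step among them is a 3.0-fold lower number from compound 1 to compound 3 (0.48 log units; beyond the scatter), a modest change that shows the group on this aromatic carbon can shift the dose.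

Compound 4 `CCCC[S+]([O-])c1nc(N)c2nc(O)n(Cc3ccccc3)c2n1` differs from compound 3 as follows: a group of 6 heavy atoms (4 carbon, 1 oxygen, 1 sulfur; no ring) in place of a group of 2 heavy atoms (1 carbon, 1 sulfur; no ring), on an aromatic carbon. Among the measured compounds shown here, no measured step covers the oxidised sulfur. What the measured compounds show is that a four-carbon chain at this place, as in compound 2, gives the same number as the methylsulfanyl of compound 3, and that swapping the group here moved the number only modestly in a 3.0-fold lower number from compound 1 to compound 3 (0.48 log units; beyond the scatter). A small rise in dose, or no change beyond the scatter, is therefore expected. Compound 4 is estimated at 0.3 mg/kg, within 0.1 mg/kg to 1 mg/kg, which means an expected step of a 3.0-fold higher number from compound 3 to compound 4 (0.48 log units; beyond the scatter).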

Compound 4, minimum effective dose: 1 mg/kg
For compound 4 the middle estimate is 3.3-fold (0.52 log units) below the measured one, and the stated range covers the measured number.
By their numbers in this assay, from the lowest: compounds 2 and 3 (each within the scatter of the next); then compound 1; then compound 4.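

In this assay, among these compounds, the group on this aromatic carbon turns out to matter more than the earlier compounds showed, with a 10-fold higher number from compound 3 to compound 4 (1.00 log units; beyond the scatter) as the largest step so far. Against pentylamino, which has the same count of heavy atoms, the new group still gives a 3.3-fold higher number from compound 1 to compound 4 (0.52 log units; beyond the scatter), so the count of heavy atoms alone does not set the dose at this place. No data shown here explain the rise.

Oxidised sulfur and longer chain enter together in compound 4, so the compounds shown cannot say which of the two accounts for the step. Open too, on these data alone, is what a butylsulfanyl group, a methyl group on the same oxidised sulfur, or a carboxylic acid would give on this carbon.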